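A few compounds are considered here, and "the series" means these few. Any claim that something is new, unique, unknown or untested is made for them only; others in the source may bear on it.

Working notes on the series. Compound 1 `CC(=O)c1ccc(NC(=O)CN(C(=O)c2ccccc2)S(=O)(=O)c2ccc(C)cc2)cc1` in a functional assay for inhibition, read by spectrophotometry, with a stated time of 20 min, tested at 4 mg/mL (on this read-out lower numbers stand for a weaker effect and higher numbers for a stronger effect at the one concentration tested), gives 18.5%. Compound 2 `CC(=O)c1ccc(NC(=O)C(CC(C)C)N(C(=O)c2ccccc2)S(=O)(=O)c2ccc(C)cc2)cc1`, which carries an isobutyl on the saturated chain carbon bound to an amide-type nitrogen and a carbonyl carbon, gives 67.3% in this assay, and compound 3 `CC(=O)c1ccc(NC(=O)CN(C(=O)c2ccccc2)S(=O)(=O)c2ccc([N+](=O)[O-])cc2)cc1`, with a nitro in place of the methyl on the aromatic carbon, gives 20.7%.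

Going by the values given here, compound 3 stands second highest of the three numbers so far. Its nearest neighbour is compound 1, and the two lie within the scatter of each other (a number 2.2 percentage points higher from compound 1 to compound 3 (within the scatter)); compound 2 lies well beyond it.

Compound 4 `CC(=O)c1ccc(NC(=O)C(CC(C)C)N(C(=O)c2ccccc2)S(=O)(=O)c2ccc([N+](=O)[O-])cc2)cc1` is not yet measured in this assay. Relative to compound 3 the change is isobutyl in place of hydrogen on a saturated chain carbon bound to an amide-type nitrogen and a carbonyl carbon. Among the compounds with values here, the one measured step that bears on it is a number 48.8 percentage points higher from compound 1 to compound 2 (beyond the scatter), the same exchange made on the core of compound 1. A step of similar size and in the same direction is therefore expected, and the estimated step is a number 47.3 percentage points higher from compound 3 to compound 4 (beyond the scatter). Compound 4 is expected to give about 68% in this assay, with a range from 50% to 85%.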

Compound 4, a percentage reported as inhibition, at one concentration (the size of the read-out at that concentration, not a potency): 71%
Estimate against measurement, compound 4: 3 percentage points below; the range from low to high includes it.
By their numbers in this assay, from the lowest: compounds 1 and 3 (each within the scatter of the next); then compounds 2 and 4 (each within the scatter of the next).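

The isobutyl in place of hydrogen on the saturated chain carbon bound to an amide-type nitrogen and a carbonyl carbon now also holds with nitro on the aromatic carbon in this assay, giving a number 50.3 percentage points higher from compound 3 to compound 4 (beyond the scatter). The gain at this position is thus seen with both methyl and nitro on the aromatic carbon: the same change on two cores in this assay, a number 48.8 percentage points higher (beyond the scatter) from compound 1 to compound 2 and a number 50.3 percentage points higher (beyond the scatter) from compound 3 to compound 4, 1.5 percentage points apart, within the scatter of two such steps. With isobutyl present, nitro in place of methyl again makes no difference beyond the scatter, giving a number 3.7 percentage points higher from compound 2 to compound 4 (within the scatter), so the two changes read as independent across these four compounds: the same change on two cores in this assay, a number 2.2 percentage points higher (within the scatter) from compound 1 to compound 3 and a number 3.7 percentage points higher (within the scatter) from compound 2 to compound 4, 1.5 percentage points apart, within the scatter of two such steps.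

As far as these compounds go, it remains open whether a methyl, a benzyl or a longer chain on this saturated carbon would give a step of similar size, or whether a carboxylic acid or an amine there would keep it. From the compounds shown here alone, it is also open whether an amine in place of nitro on the aromatic carbon would leave the number unchanged.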